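The source may hold more compounds than are shown below. What is called first, only, known or untested is meant among the compounds shown, and "the series" means these compounds.

Measured so far:
compound 1 `N#CC1=C(N)Oc2c(c3nc4ccccc4nc3c3ccccc23)C12C(=O)N(Cc1cnnn1-c1ccc(S(N)(=O)=O)cc1)c1ccccc12`: 31200 nM
compound 2 `Cc1ccc(-n2nncc2CN2C(=O)C3(C(C#N)=C(N)Oc4c3c3nc5ccccc5nc3c3ccccc43)c3ccccc32)c(C)c1`: > 50000 nM

In a functional assay on HCT-116 cells (Homo sapiens) for antiproliferative activity, read by MTT assay, with a stated time of 48 h (a higher number here means a weaker inhibitor, a lower number a stronger inhibitor), compound 1 gives 31200 nM. For compound 2 only a limit is reported in this assay, namely > 50000 nM. Compound 2 thus stands at the weak end of the two numbers shown, without an exact value. Among the compounds with values here, the single measured step, an at least 1.6-fold higher number from compound 1 to compound 2 (0.20 log units; that floor lies within the scatter), sets only a floor, since compound 2 sits at the limit of > 50000 nM in this assay, at which 1 of the 2 values shown sits. Compound 3 `N#CC1=C(N)Oc2c(c3nc4ccccc4nc3c3ccccc23)C12C(=O)N(Cc1cnnn1-c1cc(Cl)ccc1Cl)c1ccccc12` carries 2,5-dichlorophenyl in place of 2,4-dimethylphenyl on an aromatic nitrogen. Within the data shown here, no measured step swaps one carbon-only aromatic ring for another on this nitrogen, so no direction is expected beyond the scatter in this assay. The estimated step is a number no higher from compound 2 to compound 3 (the limit leaves the size open). For compound 3 the expected value in this assay is 50000 nM, within 20000 nM to 120000 nM.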

Compound 3, half-maximal inhibitory concentration: > 50000 nM
Compound 3 gave a limit, no number; the forecaster's own chance of this, stated with the estimate: 55%; the middle value sits exactly at the limit.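

In this assay compound 3 is reported only as a limit (> 50000 nM). The change from 4-sulfamoylphenyl to 2,5-dichlorophenyl on the aromatic nitrogen gives an at least 1.6-fold higher number from compound 1 to compound 3 (0.20 log units; that floor lies within the scatter) and so sets only a floor, while a second ring of carbon only now sits at the limit with compound 2: (the limit of > 50000 nM in this assay, at which 2 of the 3 values shown sit). The step between compound 2 and compound 3 cannot be read, so 2,4-dimethylphenyl and 2,5-dichlorophenyl cannot be ordered.

Whether 4-sulfamoylphenyl truly separates compound 1 from the other two stays unresolved, with both floors within the scatter. On these data alone, how a phenyl ring carrying an amine or a carboxylic acid on this nitrogen would read in this assay also stays open.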